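The compounds below may be only part of what the source reports. "The series", "measured", "known", "first", "only" and "open" are said of these compounds alone.

Measured so far in this series:
- compound 1 `Cc1c(-c2cc(Cl)cc(Cl)c2)c(C(=O)O)nn1-c1nc(-c2cc(Cl)ccc2F)c(SC(C)C)s1`: 4800 nM
- compound 2 `Cc1cc(C#N)cc(-c2c(C)nn(-c3nc(-c4ccc(Cl)c(Cl)c4)c(SC(C)C)s3)c2C(=O)O)c1`: 4800 nM
- compound 3 `Cc1nn(-c2nc(-c3ccc(Cl)c(Cl)c3)c(SC(C)C)s2)c(C(=O)O)c1-c1cnccn1`: 14000 nM

Among the compounds with values here, in a functional assay on BJAB cells (Homo sapiens) for antiproliferative activity, with a stated time of 4 days (a lower number here means that less compound is needed, a higher number that more compound is needed for the effect), compound 1 stands level with compound 2 at the digits printed, the two together the lowest of the three numbers; compound 3 lies furthest away, the only single step in hand being a 2.9-fold higher number from compound 2 to compound 3 (0.46 log units; beyond the scatter).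

Compound 4 `Cc1c(-c2cc(Cl)cc(Cl)c2)c(C(=O)O)nn1-c1nc(-c2cc(Cl)cc(Cl)c2)c(SC(C)C)s1` differs from compound 1 by 3,5-dichlorophenyl in place of 5-chloro-2-fluorophenyl on an aromatic carbon. Within the data shown here, no measured step touches this position on the five-membered ring with one nitrogen and one sulfur; the one available step concerns the other aryl group. With nothing pointing either way, no step beyond the scatter is expected in this assay. Compound 4 is estimated at 4200 nM (range 1500 nM to 12000 nM), the expected step being a 1.1-fold lower number from compound 1 to compound 4 (0.06 log units; within the scatter).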

Compound 4, half-maximal effective concentration: 2000 nM
Beside the measured number, compound 4's estimate is 2.1-fold (0.32 log units) above it; the range from low to high includes it.
By their numbers in this assay, from the lowest: compound 4; then compounds 1 and 2 (each within the scatter of the next); then compound 3.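

This position, the aromatic carbon next to the ring nitrogen, responds in this assay: 3,5-dichlorophenyl in place of 5-chloro-2-fluorophenyl gives a 2.4-fold lower number from compound 1 to compound 4 (0.38 log units; beyond the scatter), the first step read here and the only one in hand that lowers the number. Both groups count the same heavy atoms, so that count does not separate them. Nothing measured here accounts for the step.

Open, on these data alone, is whether the step holds with another aryl group on the shared core, as in compound 2 or compound 3. Also open, as far as these compounds go, is how an amine or a carboxylic acid on this phenyl ring would read.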